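Hydroxamate sulfamides: extending the aryl group of compound 2

The source may report more compounds than this note shows. Statements on the series, on what has been measured and on what is new or still open speak of the compounds shown alone.

Measured so far:
compound 1, `C[C@@H](NS(=O)(=O)N1CCC(c2ccc(Cl)cc2)CC1)C(=O)NO`: 5800 nM
compound 2, `O=C(NO)[C@H]1CCCCN1S(=O)(=O)N1CC=C(c2ccccc2)CC1`: 240 nM

In a functional assay on MONO-MAC-6 cells (Homo sapiens) for inhibition (on this read-out higher numbers stand for weaker inhibition and lower numbers for stronger inhibition), compound 2 gives 240 nM, the lowest of the two numbers; compound 1 gives 5800 nM, a gap beyond the scatter. Compound 3, `O=C(NO)[C@H]1CCCCN1S(=O)(=O)N1CC=C(c2ccc(-c3ccccc3)cc2)CC1`, carries phenyl in place of hydrogen on an aromatic carbon, para to a large group. Among the measured compounds shown here, no comparable step between measured compounds exists, so the direction rests on compound 2 alone. A step from compound 2 to compound 3 of a 1.6-fold lower number from compound 2 to compound 3 (0.20 log units; within the scatter) is expected, at the edge of the scatter, leaning toward stronger inhibition. Compound 3 is estimated at 150 nM, within 40 nM to 700 nM.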

Compound 3, half-maximal inhibitory concentration: 19000 nM
For compound 3 the middle estimate is 130-fold (2.10 log units) below the measured one; the whole stated range lies below it.
By their numbers in this assay, from the lowest: compound 2; then compound 1; then compound 3.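

In this assay phenyl in place of hydrogen on an aromatic carbon, para to a large group, gives a 79-fold higher number from compound 2 to compound 3 (1.90 log units; beyond the scatter) and so marks this position as highly sensitive to this change. A single added aromatic ring here is enough to lose most of the inhibition seen with compound 2, a sensitivity that compounds 1 and 2 could not reveal. Going by these compounds, whether a smaller group at this place, such as fluorine or methoxy, or an amine on the added phenyl would retain inhibition remains open. No measurement shown bears on why the step is so large.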